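The source may hold more compounds than are shown below. What is called first, only, known or untested is meant among the compounds shown, and "the series" means these compounds.

Measured so far: compound 1, `C=CC1=C(C(=O)NCCC)C(c2ccc(F)cc2)OC1`; compound 2, `C=CC1=C(C(=O)NC2CCCCC2)C(c2ccc(OC)c(OC)c2)OC1`; compound 3, `C=CC1=C(C(=O)NC2CCCCC2)C(c2ccc(F)cc2)OC1`.

In a functional assay on SW480 cells (Homo sapiens) for cytotoxicity, read by MTT assay, with a stated time of 24 h (on this read-out higher numbers stand for weaker inhibition and lower numbers for stronger inhibition), compound 1 gives > 100000 nM, which is a limit of the assay rather than a number. Compound 3 also gives only a limit, > 100000 nM. For the measured compounds named here, compound 2 gives 19100 nM, the only real number among the three. The difference between the core of compound 2 and the core of compound 3 is not broken down here. From compound 3 to compound 1 the change is propyl in place of cyclohexyl on an amide-type nitrogen, and its step is a step that the two limits leave unreadable from compound 3 to compound 1 since both values sit at the limit of > 100000 nM in this assay, at which 2 of the 3 values shown sit.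

Compound 4, `C=CC1=C(C(=O)NCCC)C(c2ccc(OC)c(OC)c2)OC1`, carries the same change made on compound 2: propyl in place of cyclohexyl on an amide-type nitrogen. The step from compound 2 to compound 4 is expected to be a 1.8-fold higher number from compound 2 to compound 4 (0.26 log units; within the scatter), a guess that rests on compound 2 at 19100 nM and on the unreadable a step that the two limits leave unreadable from compound 3 to compound 1. Compound 4 is therefore estimated at 35000 nM, expected between 10000 nM and 120000 nM.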

Compound 4, half-maximal inhibitory concentration: > 100000 nM
Compound 4: a limit, no number; the forecaster's own chance of this, stated with the estimate: 35%; at least 2.8-fold (0.45 log units) between middle value and limit.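

Propyl in place of cyclohexyl on the amide-type nitrogen of the core of compound 2 gives an at least 5.2-fold higher number from compound 2 to compound 4 (0.71 log units; beyond the scatter) in this assay and so weakens inhibition in this one pair. The same change on the core of compound 3 cannot be read, so nothing here shows that the change behaves alike on two cores. The size of the step is only a minimum, because compound 4 sits at a limit of the assay and not at a number: the limit of > 100000 nM in this assay, at which 3 of the 4 values shown sit.

The compounds shown leave open whether a longer chain such as hexyl on that nitrogen would match or beat compound 2. They also leave open how a chain ending in an amine or a carboxylic acid would read in this assay on either core.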